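Aryl ketone variation across the shared core

The source may hold more compounds than are shown below. What is called first, only, known or untested is meant among the compounds shown, and "the series" means these compounds.

Three compounds share one core and were run in a functional assay on COLO 205 cells (Homo sapiens) for inhibition, read by sulforhodamine B assay, with a stated time of 48 h; a higher number here means a weaker inhibitor of growth, a lower number a stronger inhibitor of growth. Compound 1 `COc1cc(-c2cc(/C=C/C(=O)c3ccc(N)cc3)[nH]n2)cc(OC)c1OC` gives 3340 nM. Compound 2 `COc1ccc(-c2cc(/C=C/C(=O)c3ccc(OC)c(OC)c3)[nH]n2)cc1` gives 3300 nM, and compound 3 `COc1cc(C(=O)/C=C/c2cc(-c3cc(OC)c(OC)c(OC)c3)n[nH]2)cc(OC)c1OC` gives 3130 nM. Compound 1 carries the highest of the three numbers, but both gaps stay within the usual scatter, so no order can be read from these three values. Compound 4 `COc1cc(-c2cc(/C=C/C(=O)c3ccc(F)c(F)c3)[nH]n2)cc(OC)c1OC` remains to be measured. It differs from compound 1 in one place: 3,4-difluorophenyl in place of 4-aminophenyl on a carbonyl carbon. Among the compounds with values here, no measured pair shows this change, so no measured step sets its size. The three measured numbers lie within the scatter of one another across different groups on the carbonyl carbon; on that basis the move from compound 1 to compound 4 is expected to stay within the scatter in this assay, with no clear direction. For compound 4 the estimate is 3000 nM, with a range from 1000 nM to 9000 nM. Accordingly a 1.1-fold lower number from compound 1 to compound 4 (0.05 log units; within the scatter) is expected to be small.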

Compound 4, concentration for total growth inhibition: 3190 nM
Compound 4: the middle estimate sits 1.1-fold (0.03 log units) below what was measured; low and high end bracket the measured number.
By their numbers in this assay, from the lowest: compounds 3, 4, 2 and 1 (each within the scatter of the next).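

Within the data shown here, this is the first one-place step: in this assay, 3,4-difluorophenyl in place of 4-aminophenyl on a carbonyl carbon gives a 1.0-fold lower number from compound 1 to compound 4 (0.02 log units; within the scatter), which is within the scatter. At this place, a group with a hydrogen-bond donor and acceptor and a group with neither therefore give values that cannot be told apart. No supporting data bear on the reason for this. Open, as far as these compounds go, is whether any group on this carbonyl carbon moves the value beyond the scatter. A straight alkyl chain or a benzoic acid group there would test this.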